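The source may hold more compounds than are shown below. What is called first, only, known or untested is meant among the compounds shown, and "the series" means these compounds.

Measured compounds in an assay on isolated protein for displacement of a labelled ligand from melanin-concentrating hormone receptor 1 (Homo sapiens); a lower number here means a stronger inhibitor, a higher number a weaker inhibitor:
compound 1, `CCCc1cc(N)c2cc(NC(=O)/C=C/c3ccc(Cl)cc3)ccc2n1`, gives 6 nM.
compound 2, `CCCc1cc(N)c2cc(NC(=O)/C=C/c3ccc(Cl)cc3Cl)ccc2n1`, gives 6.6 nM.
compound 3, `CCCc1cc(N)c2cc(NC(=O)/C=C/c3ccc(F)cc3)ccc2n1`, gives 130 nM.

Compound 3 stands highest of the three numbers in this assay. Its nearest neighbour is compound 2, reached by a 20-fold higher number from compound 2 to compound 3 (1.29 log units; beyond the scatter), and compound 1 lies furthest, reached by a 22-fold higher number from compound 1 to compound 3 (1.34 log units; beyond the scatter). Compounds 1 and 2 sit together, separated only by a 1.1-fold higher number from compound 1 to compound 2 (0.04 log units; within the scatter).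

Compound 4, `CCCc1cc(N)c2cc(NC(=O)/C=C/c3ccc(N)cc3)ccc2n1`, has not been measured. It differs from compound 3 in one place: amino in place of fluoro on an aromatic carbon.

The step that bears most directly on this change is a 22-fold higher number from compound 1 to compound 3 (1.34 log units; beyond the scatter), which shows that the group on this aromatic carbon moves the number strongly when chloro gives way to fluoro. The step of a 20-fold higher number from compound 2 to compound 3 (1.29 log units; beyond the scatter) points the same way, while a 1.1-fold higher number from compound 1 to compound 2 (0.04 log units; within the scatter) shows a chloro elsewhere on the ring leaves the number unchanged. For the measured compounds named here, no measured step goes from fluoro to amino, so the direction of the change is open; the measured steps only show that a swap at this position can be large. Compound 4 is therefore estimated near compound 3, with a wide range, at 150 nM (40 nM to 600 nM), which is expected to mean a 1.2-fold higher number from compound 3 to compound 4 (0.06 log units; within the scatter).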

Compound 4, half-maximal inhibitory concentration: 190 nM
Beside the measured number, compound 4's estimate is 1.3-fold (0.10 log units) below it; measured number inside the range.
By their numbers in this assay, from the lowest: compounds 1 and 2 (each within the scatter of the next); then compounds 3 and 4 (each within the scatter of the next).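

In this assay amino and fluoro on this aromatic carbon cannot be told apart, with a 1.5-fold higher number from compound 3 to compound 4 (0.16 log units; within the scatter) and within the scatter, although amino carries a hydrogen-bond donor and a hydrogen-bond acceptor that fluoro does not. The large rise seen on leaving chloro is therefore not particular to fluoro: it recurs with amino as a 32-fold higher number from compound 1 to compound 4 (1.50 log units; beyond the scatter) and, where the 2,4-dichlorophenyl group is replaced as a whole, as a 29-fold higher number from compound 2 to compound 4 (1.46 log units; beyond the scatter) in a step that also removes the second chloro. Across these four compounds, the two with chloro on this carbon form the low group and the two with fluoro or amino form the high group, but no measurement shown here accounts for that split.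

Going by these compounds, whether bromo, methyl or trifluoromethyl on this carbon would join compounds 1 and 2 or compounds 3 and 4 stays open, as does the number that hydrogen would give here. Also open, on these data alone, is whether dimethylamino or acetamido would stay with amino in the high group or move the number in either direction.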